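Replacing the 4-chloropiperidin-1-yl group of compound 2

The source may hold more compounds than are shown below. What is called first, only, known or untested is meant among the compounds shown, and "the series" means these compounds.

Compound 1 `CCc1nc2cc(Cl)ccn2c1C(=O)NCc1ccc(-c2ccc[nH]2)cc1` carries a 1H-pyrrol-2-yl group on the shared core. In an ADME assay (liver) for metabolic stability, with Liver microsome (Homo sapiens) as the target, using microsomes (a lower number here means that the compound disappears faster, a higher number that the compound lasts longer), compound 1 gives > 2 h, which is a limit and not a number. For the measured compounds named here, compound 2 `CCc1nc2cc(Cl)ccn2c1C(=O)NCc1ccc(N2CCC(Cl)CC2)cc1` carries 4-chloropiperidin-1-yl at that place, and in this assay compound 2 gives 0.183 h, the only actual number so far. Going by the values given here, the single measured step, an at least 10-fold lower number from compound 1 to compound 2 (1.03 log units; beyond the scatter), is large and lies beyond the scatter. That step starts from the limit of > 2 h in this assay, at which 1 of the 2 values shown sits.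

Compound 3 `CCc1nc2cc(Cl)ccn2c1C(=O)NCc1ccc(-n2cc3c(c2)CCCC3)cc1` changes the same place: a group of 9 heavy atoms (8 carbon, 1 nitrogen; one five-membered aromatic ring with 1 hetero atom, one six-membered non-aromatic ring of carbon only) in place of a group of 7 heavy atoms (5 carbon, 1 nitrogen, 1 chlorine; one six-membered non-aromatic ring with 1 hetero atom), on an aromatic carbon. The entering group holds a five-membered aromatic ring with 1 hetero atom, as the group of compound 1 does, together with a six-membered non-aromatic ring of carbon only. Among the compounds with values here, with an at least 10-fold lower number from compound 1 to compound 2 (1.03 log units; beyond the scatter) as the only guide, a partial move back in the opposite direction is expected in this assay, so a higher number but a smaller change. The expected step is a 3.3-fold higher number from compound 2 to compound 3 (0.52 log units; beyond the scatter). For compound 3 the estimated half-life is 0.6 h, with an expected range from 0.2 h to 2 h.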

Compound 3, half-life: 0.455 h
Compound 3: the middle estimate sits 1.3-fold (0.12 log units) above what was measured, and the stated range covers the measured number.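

A five-membered aromatic ring with 1 hetero atom at this place, on an aromatic carbon para to a large group, is not enough on its own to keep the long half-life seen with 1H-pyrrol-2-yl in this assay: the larger group gives an at least 4.3-fold lower number from compound 1 to compound 3 (0.64 log units; beyond the scatter). Compound 1 gives a limit and not a number, so that step has only a lower bound: the limit of > 2 h in this assay, at which 1 of the 3 values shown sits.

Set against 4-chloropiperidin-1-yl, the same entering group gives a 2.5-fold higher number from compound 2 to compound 3 (0.40 log units; beyond the scatter), so compound 3 falls between the other two compounds, and both of its steps lie beyond the scatter.

The compounds shown cannot separate the part played by the five-membered aromatic ring in compound 3 from that of its six-membered non-aromatic ring of carbon only. They also leave open how the half-life would respond at this place to plain piperidin-1-yl, which lacks the chlorine of compound 2, or to an open chain such as butyl, an amine or a carboxylic acid.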